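Chloro in Place of Methoxy: Expectation for Compound 4

A few compounds are considered here, and "the series" means these few. Any claim that something is new, unique, unknown or untested is made for them only; others in the source may bear on it.

Compound 1, `COc1cc(Cl)nc(NC(=S)NC(=O)c2c(-c3ccc(Cl)cc3Cl)noc2C)n1`: 18.5%
Compound 2, `COc1cc(OC)n2s/c(=N\C(=O)c3c(-c4ccc(Cl)cc4Cl)noc3C)nc2n1`: 43.2%
Compound 3, `COc1cc(OC)nc(NC(=S)NC(=O)c2c(-c3ccc(Cl)cc3Cl)noc2C)n1`: 21.8%

Three compounds were measured in a functional assay on the whole organism (strain L.) for inhibition, with Echinochloa crus-galli as the target, with a stated time of 72 h, tested at 10 mg/L; on this read-out higher numbers stand for more inhibition of growth at the one concentration tested and lower numbers for less inhibition of growth. Compound 2 gives the highest number, 43.2%, and its distance to compound 3 and to compound 1 is beyond the scatter in both cases. How the core of compound 2 differs from the core of compound 3 is not broken down here.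

Between compound 3 and compound 1 the only difference is chloro in place of methoxy on an aromatic carbon. In this assay this change gave a number 3.3 percentage points lower from compound 3 to compound 1 (within the scatter).

Compound 4, `COc1cc(Cl)nc2n/c(=N/C(=O)c3c(-c4ccc(Cl)cc4Cl)noc3C)sn12`, has not yet been measured. It differs from compound 2 by chloro in place of methoxy on an aromatic carbon. This is the same kind of change as that from compound 3 to compound 1, though not the same: in compound 4 the aromatic carbon belongs to a six-membered aromatic ring that is part of a fused or bridged system of two rings, meta to a fused ring and para to a fused ring, whereas in compound 1 it is meta to a large group and not part of a fused system.

Because the earlier step of a number 3.3 percentage points lower from compound 3 to compound 1 (within the scatter) stayed within the scatter, the step from compound 2 to compound 4 is expected to be small as well, estimated as a number 3.2 percentage points lower from compound 2 to compound 4 (within the scatter). Compound 4 is therefore expected to come out near 40%, estimated to lie between 25% and 55%.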

Compound 4, percent growth inhibition at one concentration: 10.8%
Compound 4: middle estimate off by 29.2 percentage points, on the high side; the whole stated range lies above it.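

In this assay chloro in place of methoxy on an aromatic carbon gave a number 32.4 percentage points lower from compound 2 to compound 4 (beyond the scatter), a large step on the core of compound 2, whereas the same change on the core of compound 3 stayed within the scatter. The size of this step therefore cannot be carried over from one core to the other in this series, and a small step on one core gives no assurance of a small step on the other. With only two such pairs, the result does not show which feature of the two cores sets the size of the step, or whether the same gap would appear at any concentration other than the one tested, but the gap itself is clear: the same change on two cores in this assay, a number 3.3 percentage points lower (within the scatter) from compound 3 to compound 1 and a number 32.4 percentage points lower (beyond the scatter) from compound 2 to compound 4, 29.1 percentage points apart, beyond the scatter of two such steps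

The compounds shown leave open whether the loss on the core of compound 2 is particular to chloro or would follow any replacement of that methoxy group. From the compounds shown here alone, an amine or an ethoxy group on the same aromatic carbon, on both cores, would help separate these two readings, and it also remains open how the remaining methoxy group on the core of compound 4 contributes.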